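Swapping the Group on the Carbonyl: Expected Cytotoxicity

A few compounds are considered here, and "the series" means these few. Any claim that something is new, unique, unknown or untested is made for them only; others in the source may bear on it.

Measured so far:
- compound 1 `Cc1ccc(-c2nn(-c3ccccc3)cc2-c2nc3ccccc3n2C(=O)c2ccccc2C)cc1`: 176000 nM
- compound 2 `Cc1ccc(C(=O)n2c(-c3cn(-c4ccccc4)nc3-c3ccc(F)cc3)nc3ccccc32)cn1`: 137000 nM

Both compounds were tested in an ADME assay on HEK-293T cells (Homo sapiens) for cytotoxicity, read by MTT assay, with a stated time of 24 h; a higher number here means that more compound is tolerated, a lower number that less compound is tolerated. Compound 1 gives 176000 nM there, and compound 2 gives 137000 nM. Compound 2 holds the lowest of the two numbers, but its gap to compound 1 lies within the scatter, so the two values show no real difference in how much compound the cells tolerate.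

The next step leads from compound 2 to compound 3 `O=C(c1ccc(Cl)cc1)n1c(-c2cn(-c3ccccc3)nc2-c2ccc(F)cc2)nc2ccccc21`, which has not yet been measured in this assay. The change is 4-chlorophenyl in place of 6-methylpyridin-3-yl on a carbonyl carbon.

For the measured compounds named here, since no step between measured compounds is available, the expectation for compound 3 rests on the two values alone, which sit close together. The step from compound 2 to compound 3 is estimated to be small, a 1.1-fold lower number from compound 2 to compound 3 (0.04 log units; within the scatter), with no direction beyond the scatter. Compound 3 is therefore expected to give about 125000 nM in this assay, estimated to lie between 50000 nM and 280000 nM.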

Compound 3, half-maximal cytotoxic concentration: 179000 nM
The estimate for compound 3 lay 1.4-fold (0.16 log units) below the measured number; measured number inside the range.
By their numbers in this assay, from the lowest: compounds 2, 1 and 3 (each within the scatter of the next).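

For the compounds shown here, this step is the first comparison here that isolates a single place, since compound 1 and compound 2 differ in more than one. In this assay, putting 4-chlorophenyl in place of 6-methylpyridin-3-yl on a carbonyl carbon gives a 1.3-fold higher number from compound 2 to compound 3 (0.12 log units; within the scatter), so this exchange produces no difference that can be told from the scatter. The entering group has a six-membered aromatic ring of carbon only and no hydrogen-bond acceptor, whereas the leaving group has a ring hetero atom and a hydrogen-bond acceptor, yet for this pair the cells' tolerance does not separate the two, and no measurement at hand offers an explanation for the result.

Both groups compared at this place are six-membered aromatic rings of equal heavy-atom count, so the compounds shown leave open how the cells would tolerate something of a different kind on the carbonyl carbon, such as an amine, a carboxylic acid or a longer alkyl chain. They also leave open whether the same exchange would read alike on the core of compound 1.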